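Adding a methoxy group to compound 2

This account rests on a few compounds, and the source may have more. Where it says the series, first, only, none or still open, it means among the compounds named here.

- compound 1 `COc1ccc(-c2nc3sc(-c4ccccc4)cn3n2)cc1`: 24%
- compound 2 `Clc1ccc(-c2cn3nc(-c4ccccc4)nc3s2)cc1`: 21%

Both compounds were tested in a functional assay on SF-539 cells (Homo sapiens) for inhibition, read by sulforhodamine B assay, with a stated time of 48 h, tested at 10 uM; a lower number here means less inhibition of growth, a higher number more inhibition of growth at the concentration tested. Compound 1 gives 24% and compound 2 gives 21%. Within the data shown here, these two values lie within the usual scatter of each other, so compound 2 cannot be told apart from compound 1 on the numbers so far.

Compound 3 `COc1ccc(-c2nc3sc(-c4ccc(Cl)cc4)cn3n2)cc1` is compound 2 with one structural change: methoxy in place of hydrogen on an aromatic carbon. This puts methoxy in place of hydrogen on an aromatic carbon, para to a large group. Compound 1 also carries a methoxy group, but it differs from compound 2 in more than one place. Among the measured compounds shown here, no measured pair therefore shows this change on its own, and the size of its effect has to be estimated.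

In this assay, no step beyond the scatter is expected, and no firm direction either. The expected change a number 3 percentage points higher from compound 2 to compound 3 (within the scatter) is small. For compound 3 the estimated value is 24%, with an expected range of 8% to 42%.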

Compound 3, percent growth inhibition at one concentration: 84.6%
Compound 3: the middle estimate sits 60.6 percentage points below what was measured; measured number above the stated range.
By their numbers in this assay, from the lowest: compounds 2 and 1 (each within the scatter of the next); then compound 3.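

In this assay, placing methoxy on an aromatic carbon, para to a large group, gives a number 63.6 percentage points higher from compound 2 to compound 3 (beyond the scatter), so this position on the ring of compound 2 is far from indifferent to substitution. Compound 1 already carries a methoxy group and still sits low, yet adding chloro in place of hydrogen on an aromatic carbon gives a number 60.6 percentage points higher from compound 1 to compound 3 (beyond the scatter), so among these three compounds the high value appears only where methoxy and chloro are present together, and each single change makes a large difference only with the other group already in place. Nothing available explains why this combination stands out from the two compounds carrying one group alone.

Going by these compounds, whether methoxy itself is needed at this position remains open, since an ethoxy group, a hydroxyl group or an amine in the same place could give a high or a low value. On these data alone, it is equally open whether chloro can be exchanged for another halogen such as bromine or fluorine while keeping the high growth inhibition seen with compound 3 .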